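Notes on the side group, compound 2 to compound 3

A few compounds are considered here, and "the series" means these few. Any claim that something is new, unique, unknown or untested is made for them only; others in the source may bear on it.

Compound 1 `COC(=O)C1=C(C)N=C(C)/C(=C(/O)OC)C1c1cccc(OCCO[N+](=O)[O-])c1` gives 750 nM
Compound 2 `COC(=O)C1=C(C)N=C(C)/C(=C(/O)OC)C1c1cccc(OCc2nonc2C)c1` gives 640 nM
Compound 3 `COC(=O)C1=C(C)N=C(C)/C(=C(/O)OC)C1c1cccc(OCc2c(C)no[n+]2[O-])c1` is not yet measured

Both values come from a functional assay (aorta) with Rattus norvegicus as the target, in the presence of a further agent that is not named here (a lower number here means that less compound is needed, a higher number that more compound is needed for the effect), and compound 2 sits within the scatter of compound 1, so neither ranks ahead of the other. The next change keeps the shared core and alters only the side group: a group of 7 heavy atoms (3 carbon, 2 nitrogen, 2 oxygen; one five-membered aromatic ring with 3 hetero atoms) in place of a group of 6 heavy atoms (3 carbon, 2 nitrogen, 1 oxygen; one five-membered aromatic ring with 3 hetero atoms), on a saturated chain carbon bound to an oxygen on an aromatic ring. Going by the values given here, one measured step bears on it. That step, a 1.2-fold lower number from compound 1 to compound 2 (0.07 log units; within the scatter), exchanged (nitrooxy)methyl for 4-methyl-1,2,5-oxadiazol-3-yl and stayed within the scatter. Among the compounds with values here, this is thin evidence, as no measured compound yet carries the entering group, so the range has to stay wide. Still, the only replacement seen so far in this part of the series produced no step beyond the scatter in this assay, and none is expected here in either direction. The expected change is a 1.1-fold lower number from compound 2 to compound 3 (0.03 log units; within the scatter) and it would not be read as a real shift. Compound 3 is estimated at 600 nM with an expected range of 220 nM to 1600 nM on this scale.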

Compound 3, half-maximal effective concentration: 400 nM
For compound 3 the middle estimate is 1.5-fold (0.18 log units) above the measured one, within the range that was stated.
By their numbers in this assay, from the lowest: compounds 3, 2 and 1 (each within the scatter of the next).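

The position on a saturated chain carbon bound to an oxygen on an aromatic ring now has a third side group, and in this assay the added oxygen of the entering group, with the ring type and the donor and acceptor counts unchanged from 4-methyl-1,2,5-oxadiazol-3-yl, amounts to a 1.6-fold lower number from compound 2 to compound 3 (0.20 log units; within the scatter) and does not separate the two ring groups. The comparison with the ring-free nitrooxy group, a 1.9-fold lower number from compound 1 to compound 3 (0.27 log units; within the scatter) as well, shows that even this larger exchange, from a group with no ring to a ring-bearing group of 7 heavy atoms, stays inside the scatter, so all three side groups in this set read alike at this position. Nothing available here accounts for the size of either step.

The compounds shown leave open whether any side group at this place can move the number beyond the scatter, for instance an amine, a carboxylic acid or a longer chain carrying the same ring. They also leave open whether the same insensitivity to the side group would hold with a different core, since all three compounds share one.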